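Changing the aryl ring on the sulfonyl sulfur

This account rests on a few compounds, and the source may have more. Where it says the series, first, only, none or still open, it means among the compounds named here.

Within the data shown here, compound 2 `COc1ccc(S(=O)(=O)c2cnc3ccc(Cl)cc3c2N2CCC(C)CC2)cc1Cl` gives 46% in an assay on isolated protein for displacement of a labelled ligand from metabotropic glutamate receptor 5 (Homo sapiens), with a stated time of 60 min, tested at 1 uM (on this read-out lower numbers stand for less inhibition and higher numbers for more inhibition at the one concentration tested (going by the name of the read-out)), the lower of the two numbers so far. Compound 1 `COc1cccc(S(=O)(=O)c2cnc3ccc(Cl)cc3c2N2CCC(C)CC2)c1` gives 87% in this assay; the step of a number 41 percentage points lower from compound 1 to compound 2 (beyond the scatter) lies beyond the scatter. Compound 3 `CC1CCN(c2c(S(=O)(=O)c3ccc(F)c(F)c3)cnc3ccc(Cl)cc23)CC1` differs from compound 2 by 3,4-difluorophenyl in place of 3-chloro-4-methoxyphenyl on a sulfonyl sulfur. Among the measured compounds shown here, the single measured step touches the same ring but swaps different groups, so it gives only weak guidance. A moderate rise is expected, a number 9 percentage points higher from compound 2 to compound 3 (within the scatter), with wide uncertainty. Compound 3 is therefore estimated at 55% in this assay, between 20% and 85%.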

Compound 3, a percentage reported as inhibition, at one concentration (the size of the read-out at that concentration, not a potency): 72%
Compound 3: middle estimate off by 17 percentage points, on the low side; measured number inside the range.
By their numbers in this assay, from the lowest: compound 2; then compound 3; then compound 1.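

In this assay the 3,4-difluorophenyl ring gives a number 26 percentage points higher from compound 2 to compound 3 (beyond the scatter) and also a number 15 percentage points lower from compound 1 to compound 3 (beyond the scatter) so it sits apart from both earlier rings. This position on the sulfonyl sulfur therefore separates all three aryl rings shown, with 3-methoxyphenyl highest and 3-chloro-4-methoxyphenyl lowest. No evidence is available to explain these differences. Still open, from the compounds shown here alone, is how an aryl ring carrying an amine or a carboxylic acid would read, and whether a ring with a single fluorine would stand nearer compound 1 or compound 3.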